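The source may hold more compounds than are shown below. What is called first, only, known or untested is meant among the compounds shown, and "the series" means these compounds.

Measured so far:
Compound 1 `CC(C)(C)CCOc1cccc(O)c1C(=O)/C=C/c1ccc(C(=O)O)cc1` gives 2800 nM in an assay on THP-1 cells for inhibition of nuclear factor NF-kappa-B complex (Homo sapiens), with stated times of 2 h and 16 h; on this read-out lower numbers stand for stronger inhibition and higher numbers for weaker inhibition.
Compound 2 `CC(C)=CCOc1cccc(O)c1C(=O)/C=C/c1ccc(O)cc1` reaches only the limit > 30000 nM in this assay.
Compound 3 `O=C(/C=C/c1ccc(O)cc1)c1c(O)cccc1OCCC1CCCCC1` likewise reaches only the limit > 30000 nM in this assay.

Compound 3 therefore has no number of its own, only a limit, and it shares that position with compound 2 at the limit of > 30000 nM in this assay, at which 2 of the 3 values shown sit. The step that the two limits leave unreadable from compound 2 to compound 3 stays unreadable for that reason. Among the compounds with values here, compound 1 does give a number, but it differs from compound 3 in two places, so no single step can be drawn from it. Compound 4 `CC(C)COc1cccc(O)c1C(=O)/C=C/c1ccc(O)cc1` differs from compound 3 by isopropyl in place of cyclohexylmethyl on a saturated chain carbon bound to an oxygen on an aromatic ring. Within the data shown here, no measured step bears directly on this change, so nothing beyond the scatter is expected. Compound 4 is therefore estimated at 30000 nM, between 6000 nM and 100000 nM. That estimate means an expected step of a number no higher from compound 3 to compound 4 (the limit leaves the size open).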

Compound 4, half-maximal inhibitory concentration: 8000 nM
Estimate against measurement, compound 4: 3.8-fold (0.57 log units) above; low and high end bracket the measured number.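

This place on the saturated chain carbon bound to an oxygen on an aromatic ring now gives its first readable change: isopropyl in place of cyclohexylmethyl gives an at least 3.7-fold lower number from compound 3 to compound 4 (0.57 log units; beyond the scatter) in this assay, and isopropyl in place of 2-methylprop-1-en-1-yl gives an at least 3.7-fold lower number from compound 2 to compound 4 (0.57 log units; beyond the scatter). So the group here can move the read-out, which compounds 2 and 3 could not show. The true size of both steps stays unknown because each starts from a limit, not a number: the limit of > 30000 nM in this assay, at which 2 of the 4 values shown sit.

From the compounds shown here alone, whether a shorter ethyl group, or a chain carrying an amine, would lower the number further stays open.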